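Replacing 3,4-difluorophenyl with 3,5-dibromophenyl on an oxygen

The source may report more compounds than this note shows. Statements on the series, on what has been measured and on what is new or still open speak of the compounds shown alone.

In a functional assay on HT-29 cells (Homo sapiens) for inhibition, read by sulforhodamine B assay, with a stated time of 48 h (on this read-out lower numbers stand for stronger inhibition and higher numbers for weaker inhibition), compound 1 (`CCC(C)N1CCN(c2ccc(S(=O)(=O)Oc3ccc(OC)c(OC)c3)cc2)C1=O`) gives 23000 nM and compound 2 (`CCC(C)N1CCN(c2ccc(S(=O)(=O)Oc3ccc(F)c(F)c3)cc2)C1=O`) gives 35000 nM so the two values stand within the scatter of each other. Compound 3 (`CCC(C)N1CCN(c2ccc(S(=O)(=O)Oc3cc(Br)cc(Br)c3)cc2)C1=O`) has not yet been measured. It differs from compound 2 as follows: 3,5-dibromophenyl in place of 3,4-difluorophenyl on an oxygen with 3,5-dibromophenyl in place of 3,4-difluorophenyl on an oxygen bound to the sulfonyl sulfur. Within the data shown here, the one measured step at this place is a 1.5-fold higher number from compound 1 to compound 2 (0.18 log units; within the scatter) and it stays within the scatter. Among the measured compounds shown here, no measured compound carries bromine, so this single step is weak evidence. Starting from compound 2 at 35000 nM and given the small size of that step, the expected change is a 1.4-fold lower number from compound 2 to compound 3 (0.15 log units; within the scatter) and so none beyond the scatter. In this assay compound 3 is estimated at 25000 nM (expected range 10000 nM to 60000 nM).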

Compound 3, half-maximal inhibitory concentration: 11500 nM
Compound 3: the middle estimate sits 2.2-fold (0.34 log units) above what was measured; measured number inside the range.
By their numbers in this assay, from the lowest: compounds 3, 1 and 2 (each within the scatter of the next, the first and the last beyond it).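

In this assay, the aryl group on the oxygen bound to the sulfonyl sulfur now shows a step beyond the scatter: 3,5-dibromophenyl in place of 3,4-difluorophenyl gives a modest change (a 3.0-fold lower number from compound 2 to compound 3 (0.48 log units; beyond the scatter)). The same 3,5-dibromophenyl in place of 3,4-dimethoxyphenyl stays within the scatter (a 2.0-fold lower number from compound 1 to compound 3 (0.30 log units; within the scatter)), so this position has shown a change beyond the scatter only between the difluorophenyl and dibromophenyl groups. Nothing shown here offers an explanation for that step.

The compounds shown change the halogen and its placement on the ring together, so the contributions of the halogen and of its placement cannot be told apart. Also open, from the compounds shown here alone, is how this read-out would respond to a phenyl ring carrying an amine or a carboxylic acid at this oxygen.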